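Adding Fluoro to Compound 1: An Expected Clearance

The source may report more compounds than this note shows. Statements on the series, on what has been measured and on what is new or still open speak of the compounds shown alone.

In an in vivo ADME assay on the whole organism (plasma, strain Sprague-Dawley) for pharmacokinetics, with Rattus norvegicus as the target (a lower number here means slower removal, a higher number faster removal of the compound), compound 1 (`O=C1[C@@H](NS(=O)(=O)c2ccc3c(Cl)c[nH]c3c2)CCN1c1ccc2c(c1)CCNC2`) gives 7.7 mL/min/kg, and compound 2 (`O=C1[C@@H](NS(=O)(=O)c2ccc3cc[nH]c3c2)CCN1c1ccc2c(c1)CCNC2`) gives 12 mL/min/kg. Among the measured compounds shown here, these are the only two measurements available, and they lie within the scatter of each other, so they set no firm order. Compound 3 (`O=C1[C@@H](NS(=O)(=O)c2ccc3c(Cl)c[nH]c3c2)CCN1c1cc2c(cc1F)CNCC2`) departs from compound 1 by fluoro in place of hydrogen on an aromatic carbon. This is fluoro in place of hydrogen on an aromatic carbon of a six-membered aromatic ring of carbon only, part of a fused or bridged system of two rings, ortho to a large group.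

For the measured compounds named here, no measured step adds fluoro, and none touches this place. The nearest evidence is a 1.6-fold higher number from compound 1 to compound 2 (0.19 log units; within the scatter), where hydrogen replaces chloro on an aromatic carbon elsewhere in the molecule. That step is indirect evidence, but it offers no reason to expect a change beyond the scatter in this assay. The expected move is a 1.0-fold higher number from compound 1 to compound 3 (0.02 log units; within the scatter), with no firm direction. For compound 3, the estimated clearance is 8 mL/min/kg, with an expected range from 4 mL/min/kg to 16 mL/min/kg.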

Compound 3, clearance: 1.3 mL/min/kg
The estimate for compound 3 lay 6.2-fold (0.79 log units) above the measured number, outside the stated range (below it).
By their numbers in this assay, from the lowest: compound 3; then compounds 1 and 2 (each within the scatter of the next).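

In this assay, fluoro in place of hydrogen on an aromatic carbon, ortho to a large group, gives a 5.9-fold lower number from compound 1 to compound 3 (0.77 log units; beyond the scatter). Among the compounds shown here, this shows that the place on this six-membered aromatic ring can shift clearance beyond the scatter through a change of a single heavy atom, which the earlier pair did not show: a 1.6-fold higher number from compound 1 to compound 2 (0.19 log units; within the scatter), with hydrogen in place of chloro on an aromatic carbon elsewhere in the molecule, is the only other step and stays within the scatter. Nothing measured here accounts for the lower number of compound 3, so the reason for it remains unknown.

The compounds shown leave open whether the step belongs to fluoro itself or to any substituent at this place, since a chloro, a methyl or a methoxy group on the same aromatic carbon would separate those two readings. They also leave open whether fluoro at this place would give a similar step on the core of compound 2, where hydrogen stands in place of the chloro, and whether fluoro on the other carbons of this ring would do the same.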